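From 4-Methylphenyl to Pyridin-2-yl on the Amide Nitrogen

The source may report more compounds than this note shows. Statements on the series, on what has been measured and on what is new or still open speak of the compounds shown alone.

Compound 1 `COc1cc2c(cc1OC)C(CC(=O)O)CC2`: 24%
Compound 2 `COc1cc2c(cc1OC)C(CC(=O)Nc1ccc(C)cc1)CC2`: 26%

In a functional assay on the whole organism (strain Wistar) for inhibition, with Rattus norvegicus as the target, read by paw edema, with a stated time of 2 h, at a dose of 100 mg/kg (on this read-out lower numbers stand for less inhibition and higher numbers for more inhibition at the one dose given (going by the name of the read-out)), compound 2 gives 26%, the higher of the two numbers, yet the step of a number 2 percentage points higher from compound 1 to compound 2 (within the scatter) lies within the scatter, so no order between the two can be claimed. Compound 3 `COc1cc2c(cc1OC)C(CC(=O)Nc1ccccn1)CC2` differs from compound 2 by pyridin-2-yl in place of 4-methylphenyl on an amide-type nitrogen. For the measured compounds named here, the only measured step, a number 2 percentage points higher from compound 1 to compound 2 (within the scatter), brought in the (4-methylphenyl)amino group and stayed within the scatter; nothing measured tests replacing that aryl group itself. I therefore expect no step beyond the scatter, no change at the digits printed from compound 2 to compound 3 (within the scatter), and estimate compound 3 at 26%, ranging from 14% to 38%.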

Compound 3, a percentage reported as inhibition, in the whole organism at one dose (the size of the read-out at that dose, not a potency): 32%
Estimate against measurement, compound 3: 6 percentage points below, and the stated range covers the measured number.
By their numbers in this assay, from the lowest: compounds 1, 2 and 3 (each within the scatter of the next).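

For the compounds shown here, this is the first measured test of the aryl group itself: pyridin-2-yl in place of 4-methylphenyl on the amide-type nitrogen gives a number 6 percentage points higher from compound 2 to compound 3 (within the scatter) and so leaves the two compounds indistinguishable. Set against the acid, (pyridin-2-yl)amino in place of hydroxy gives a number 8 percentage points higher from compound 1 to compound 3 (within the scatter) and likewise separates neither compound from the other. No evidence is available that bears on these numbers.

Open, on these data alone, is whether a pyridin-3-yl, pyridin-4-yl or cyclohexyl group on the same nitrogen would give a step beyond the scatter.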